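The compounds below may be only part of what the source reports. "The series", "measured", "known", "first", "only" and "open" are said of these compounds alone.

Compound 1 `COc1cccc(Sc2cccc(N)c2C#N)c1`: > 200000 nM
Compound 2 `Cc1ccccc1Sc1cccc(N)c1C#N`: > 40000 nM
Compound 3 `Cc1ccc(Sc2cccc(N)c2C#N)cc1`: > 200000 nM

Each of these entries from a functional assay on MT4 cells (Homo sapiens) for cytotoxicity (on this read-out lower numbers stand for stronger inhibition and higher numbers for weaker inhibition), is a limit, not a number. Compound 2 therefore stands only at its limit of > 40000 nM. Compound 4 `N#Cc1c(N)cccc1Sc1ccccc1Br` has not yet been measured. It differs from compound 2 by bromo in place of methyl on an aromatic carbon, with bromo in place of methyl on an aromatic carbon. Going by the values given here, no measured step shows what such a change does, so no change beyond the scatter is expected in this assay, and another limit is the likeliest report. The expected step is small: a step that the limit leaves unreadable from compound 2 to compound 4. For compound 4 the estimate is 50000 nM, with an expected range from 20000 nM to 200000 nM.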

Compound 4, half-maximal inhibitory concentration: 41000 nM
Compound 4: middle estimate off by 1.2-fold (0.09 log units), on the high side; measured number inside the range.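

Going by these compounds alone, compound 2 is known only as a limit, > 40000 nM, and no step from it to compound 4 can be read. The compounds shown leave open what bromo in place of methyl on an aromatic carbon does in this assay.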